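Dropping the Methoxy: Where Compound 3 Is Expected

The compounds below may be only part of what the source reports. "The series", "measured", "known", "first", "only" and "open" are said of these compounds alone.

In a functional assay on MGC-803 cells (Homo sapiens) for antiproliferative activity, read by CCK-8 assay, with a stated time of 72 h (on this read-out higher numbers stand for weaker inhibition and lower numbers for stronger inhibition), compound 2 `COc1ccn2c(-c3ccc(NC(=O)c4ccc([N+](=O)[O-])o4)c(C)c3)cnc2c1` gives 1380 nM, the highest of the two numbers in hand. Compound 1 `O=C(Nc1ccc(-c2cnc3ccccn23)cc1)c1ccc([N+](=O)[O-])o1` gives 590 nM in this assay, a gap that lies beyond the usual scatter. Compound 3 `Cc1cc(-c2cnc3ccccn23)ccc1NC(=O)c1ccc([N+](=O)[O-])o1` differs from compound 2 by hydrogen in place of methoxy on an aromatic carbon. Compound 1, which also lacks that methoxy, sits below compound 2, so the step is expected to point downward, toward stronger inhibition, by about a 2.0-fold lower number from compound 2 to compound 3 (0.29 log units; within the scatter). Compound 3 is therefore estimated at 700 nM in this assay, within a range of 300 nM to 1600 nM.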

Compound 3, half-maximal inhibitory concentration: 1830 nM
Compound 3: middle estimate off by 2.6-fold (0.42 log units), on the low side; the whole stated range lies below it.
By their numbers in this assay, from the lowest: compound 1; then compounds 2 and 3 (each within the scatter of the next).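

In this assay hydrogen in place of methoxy, opposite the ring nitrogen, gives a 1.3-fold higher number from compound 2 to compound 3 (0.12 log units; within the scatter) and so leaves compound 2 and compound 3 indistinguishable. Methyl in place of hydrogen on an aromatic carbon gives a 3.1-fold higher number from compound 1 to compound 3 (0.49 log units; beyond the scatter) and is the step here that lies beyond the scatter, toward weaker inhibition. No evidence in hand accounts for either step. As far as these compounds go, whether an amine or a carboxylic acid would be tolerated at the methoxy position stays open. Also open, from the compounds shown here alone, is how the methoxy reads on the core of compound 1, without the methyl.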